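Thiophene in Place of Phenyl on the Hydrazide of Compound 3

This account rests on a few compounds, and the source may have more. Where it says the series, first, only, none or still open, it means among the compounds named here.

Measured compounds:
compound 1, `CCOC(=O)C1=C(C)NC(C)=C(C(=O)OCC)C1c1ccc(OCC(=O)NCc2ccccc2)cc1`: 8.33%
compound 2, `CCOC(=O)C1=C(C)NC(C)=C(C(=O)OCC)C1c1ccc(OCC(=O)Nc2nc3ccccc3s2)cc1`: 47.7%
compound 3, `CCOC(=O)C1=C(C)NC(C)=C(C(=O)OCC)C1c1ccc(OCC(=O)NNC(=O)c2ccccc2)cc1`: 9.1%

Three compounds share one core and differ only in the group carried on the amide-type nitrogen of the side chain. In a functional assay on the whole organism (strain Wistar) for inhibition, with Rattus norvegicus as the target, read by paw edema, with stated times of 30 min and 0.5 h, at a dose of 20 mg/kg (on this read-out higher numbers stand for more inhibition at the one dose given (going by the name of the read-out) and lower numbers for less inhibition), compound 1 gives 8.33%, compound 2 gives 47.7% and compound 3 gives 9.1%. Compound 3 stands second highest of the three numbers, but its nearest neighbour, compound 1, lies within the scatter (a number 0.8 percentage points higher from compound 1 to compound 3 (within the scatter)), so the two cannot be ranked against each other. Compound 2 is the furthest from compound 3, and the gap is large (a number 38.6 percentage points lower from compound 2 to compound 3 (beyond the scatter)), matching the large rise seen in a number 39.4 percentage points higher from compound 1 to compound 2 (beyond the scatter).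

Compound 4, `CCOC(=O)C1=C(C)NC(C)=C(C(=O)OCC)C1c1ccc(OCC(=O)NNC(=O)c2cccs2)cc1`, differs from compound 3 by thiophen-2-yl in place of phenyl on a carbonyl carbon. Among the measured compounds shown here, none of the measured steps bears directly on this change: all three alter the group on the amide-type nitrogen, not the ring on the carbonyl carbon. For the measured compounds named here, the data therefore offer no step of comparable kind, and the expectation for compound 4 rests on compound 3 alone, with a step expected to stay within the scatter, a number 2.9 percentage points higher from compound 3 to compound 4 (within the scatter). Compound 4 is estimated at 12%, with a range from 0% to 30%.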

Compound 4, a percentage reported as inhibition, in the whole organism at one dose (the size of the read-out at that dose, not a potency): 44%
Compound 4: middle estimate off by 32 percentage points, on the low side; the measured number lies above the stated range.
By their numbers in this assay, from the lowest: compounds 1 and 3 (each within the scatter of the next); then compounds 4 and 2 (each within the scatter of the next).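

In this assay, among the compounds shown here, the ring on the carbonyl carbon proves to be a position that can decide the outcome: thiophen-2-yl in place of phenyl gives a number 34.9 percentage points higher from compound 3 to compound 4 (beyond the scatter) and so turns a compound close to the low end of the series into one at the high end, although the earlier compounds varied only the group on the amide-type nitrogen. For the compounds shown here, compound 2 had been the only compound well clear of the low pair, but a number 3.7 percentage points lower from compound 2 to compound 4 (within the scatter) now puts a second, quite different group at its level, while a number 35.7 percentage points higher from compound 1 to compound 4 (beyond the scatter) matches in size the gain that the 1,3-benzothiazol-2-yl group gave over benzyl. Nothing available here accounts for why exchanging one aromatic ring for the other has so large an effect on this read-out.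

The compounds shown leave open whether the sulfur-bearing ring itself is needed on this carbonyl carbon, or whether furan-2-yl, thiophen-3-yl or a pyridine ring would serve as well. They also leave open whether a small group such as methyl could replace the ring there, and how the inhibition of compound 4 changes with dose.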